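Capping the amino group of compound 1 with trifluoroacetyl

The compounds below may be only part of what the source reports. "The series", "measured", "known", "first", "only" and "open" are said of these compounds alone.

Among the measured compounds shown here, compound 1 `CCCCn1c(=O)n(Cc2ccccc2F)c(=O)c2[nH]c(Cc3ccc(N)cc3)nc21` gives 2560 nM in an assay on isolated protein for inhibition of phosphoenolpyruvate carboxykinase, cytosolic [GTP] (Homo sapiens) (a higher number here means a weaker inhibitor, a lower number a stronger inhibitor), the second highest of the three numbers so far. Compound 2 `CCCCn1c(=O)n(Cc2ccccc2F)c(=O)c2[nH]c(Cc3ccc(N)cc3N)nc21`, which carries an amino in place of hydrogen on an aromatic carbon, gives 5650 nM in this assay; the step is a 2.2-fold higher number from compound 1 to compound 2 (0.34 log units; beyond the scatter). Compound 3 `Cc1noc(C)c1S(=O)(=O)Nc1ccc(Cc2nc3c([nH]2)c(=O)n(Cc2ccccc2F)c(=O)n3CC2CC2)cc1` gives 790 nM in this assay, a lower number than compound 1, but it differs from compound 1 in two places at once, so only its value itself can be taken from it.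

Compound 4 `CCCCn1c(=O)n(Cc2ccccc2F)c(=O)c2[nH]c(Cc3ccc(NC(=O)C(F)(F)F)cc3)nc21` differs from compound 1 by (trifluoromethyl)carbonyl in place of hydrogen on a nitrogen on an aromatic ring. For the measured compounds named here, no measured step covers this exact change. The step from compound 1 to compound 2 adds an amino on a carbon rather than a substituent on the nitrogen and bears on it only loosely. Going by the values given here, compound 3, the only other compound in which the nitrogen on the aromatic ring carries a substituent, shows a lower number than compound 1, but its second difference leaves that bearing uncertain. A small step in this assay toward a lower number is therefore expected for compound 4, close to the edge of the scatter. The estimate for compound 4 in this assay is 1300 nM, between 500 nM and 3500 nM, which corresponds to an expected step of a 2.0-fold lower number from compound 1 to compound 4 (0.29 log units; within the scatter).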

Compound 4, half-maximal inhibitory concentration: 2300 nM
Compound 4: middle estimate off by 1.8-fold (0.25 log units), on the low side; low and high end bracket the measured number.
By their numbers in this assay, from the lowest: compound 3; then compounds 4 and 1 (each within the scatter of the next); then compound 2.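

In this assay, placing a (trifluoromethyl)carbonyl in place of hydrogen on the nitrogen of the amino group gives a 1.1-fold lower number from compound 1 to compound 4 (0.05 log units; within the scatter), so compound 1 and compound 4 cannot be told apart. Among the compounds shown here, this is the first reading of a single change at this nitrogen, as compound 3 also carries a substituent there but differs from compound 1 in a second place, while the step to compound 2 concerns an aromatic carbon. The change from amino to ((trifluoromethyl)carbonyl)amino therefore leaves the number in this series unmoved, and no measurement at hand offers an explanation for this.

From the compounds shown here alone, whether other groups on this nitrogen behave the same way remains open: an acetyl, a methyl or a sulfonyl group, each with the rest of compound 1 unchanged, would test this. Also open, going by these compounds, is how much of the value of compound 3, 790 nM, comes from its group on the nitrogen and how much from its other difference from compound 1.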